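Benzyl Replaces Hydroxyphenyl on the Ring Nitrogen

The source may report more compounds than this note shows. Statements on the series, on what has been measured and on what is new or still open speak of the compounds shown alone.

Compound 1 `CCOC(=O)C(=O)CC(=O)/C=C/c1cn(CCC(C)C)c2ccccc12`: > 40 uM
Compound 2 `CCOC(=O)C(=O)CC(=O)/C=C/c1cn(-c2ccccc2)c2ccccc12`: > 40 uM
Compound 3 `CCOC(=O)C(=O)CC(=O)/C=C/c1cn(-c2ccc(O)cc2)c2ccccc12`: > 40 uM

In an assay on isolated protein for inhibition of DNA nucleotidylexotransferase (Homo sapiens), read by scintillation counting, with a stated time of 10 min (a higher number here means a weaker inhibitor, a lower number a stronger inhibitor), compound 1 gives > 40 uM, which is a limit of the assay and not a number. Compound 2 likewise gives > 40 uM, a limit. Compound 3 gives > 40 uM, again only a limit. Compound 3 therefore stands at the limit shared by every value here; this is the point at which all three sit (the limit of > 40 uM in this assay, at which 3 of the 3 values shown sit). The steps a step that the two limits leave unreadable from compound 1 to compound 2, a step that the two limits leave unreadable from compound 1 to compound 3 and a step that the two limits leave unreadable from compound 2 to compound 3 cannot be read, because both ends of each are limits.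

Compound 4 `CCOC(=O)C(=O)CC(=O)/C=C/c1cn(Cc2ccccc2)c2ccccc12` differs from compound 3 by benzyl in place of 4-hydroxyphenyl on an aromatic nitrogen. For the measured compounds named here, no measured step bears readably on this change, so no direction can be expected beyond the scatter in this assay; the likeliest outcome for compound 4 is another limit. Compound 4 is estimated at 60 uM, with a range from 20 uM to 200 uM, the expected step being a step that the limit leaves unreadable from compound 3 to compound 4.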

Compound 4, concentration for 50% inhibition: > 40 uM
Compound 4: a limit, no number; the forecaster's own chance of this, stated with the estimate: 80%; the middle value is on the limit's open side.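

In this assay compound 4 gives > 40 uM, again a limit and not a number. No step from compound 1, compound 2 or compound 3 to compound 4 can be read, because both ends of each are limits: the limit of > 40 uM in this assay, at which 4 of the 4 values shown sit.

The compounds shown leave open whether isopentyl, phenyl, 4-hydroxyphenyl and benzyl on the aromatic nitrogen differ in inhibition at all.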